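The source may report more compounds than this note shows. Statements on the series, on what has been measured and on what is new or still open speak of the compounds shown alone.

Measured compounds in an assay on isolated protein for inhibition of Amine oxidase [flavin-containing] B (Homo sapiens), read by fluorescence, with stated times of 15 min and 20 min; a higher number here means a weaker inhibitor, a lower number a stronger inhibitor:
- compound 1, `Cc1ccc(C2=NN(C(=O)CN3CCCCC3)C(c3ccccc3O)C2)cc1`, gives 45600 nM
- compound 2, `O=C(CN1CCCCC1)N1N=C(c2ccc(F)cc2)CC1c1ccccc1O`, gives 47400 nM

Compound 2 holds the highest of the two numbers in this assay, and its nearest neighbour is compound 1; the two are separated by a 1.0-fold higher number from compound 1 to compound 2 (0.02 log units; within the scatter), so nothing distinguishes them in this read-out. Both compounds share the same core and differ only in the group on the aromatic carbon of the outer phenyl ring.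

Compound 3, `O=C(CN1CCCCC1)N1N=C(c2ccc(Cl)cc2)CC1c1ccccc1O`, has not been measured in this assay. It differs from compound 2 by chloro in place of fluoro on an aromatic carbon. Within the data shown here, no measured step carries the same change; the only step at hand, a 1.0-fold higher number from compound 1 to compound 2 (0.02 log units; within the scatter), exchanges groups at the same aromatic carbon and stays within the scatter. On that basis no movement beyond the scatter is expected for compound 3 in this assay, and the step from compound 2 is estimated as a 1.1-fold lower number from compound 2 to compound 3 (0.02 log units; within the scatter). For compound 3 the expected value in this assay is 45000 nM, with a range of 20000 nM to 100000 nM. This expectation rests on two measured compounds only.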

Compound 3, half-maximal inhibitory concentration: 40100 nM
Compound 3: middle estimate off by 1.1-fold (0.05 log units), on the high side, within the range that was stated.
By their numbers in this assay, from the lowest: compounds 3, 1 and 2 (each within the scatter of the next).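

In this assay, the aromatic carbon para to a large group now carries a third group: the change from 4-fluorophenyl to 4-chlorophenyl gives a 1.2-fold lower number from compound 2 to compound 3 (0.07 log units; within the scatter), and chloro in place of methyl gives a 1.1-fold lower number from compound 1 to compound 3 (0.06 log units; within the scatter). All three pairs among methyl, fluoro and chloro at this carbon now lie within the scatter, so the lack of separation seen for the first pair also holds for chloro, and this read-out does not tell these three groups apart at this position. No measurement is available that bears on the reason for this flat response.

From the compounds shown here alone, whether the flat response extends to groups of another kind at this carbon, such as an amine, a carboxylic acid, a nitrile or a longer alkyl chain, remains open, as does the effect of a bare hydrogen there. Going by these compounds, every step shown sits at this one carbon, so it also remains open whether changes elsewhere on the shared core would move the number beyond the scatter.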